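Aryl group change on the amide-type nitrogen

The source may hold more compounds than are shown below. What is called first, only, known or untested is meant among the compounds shown, and "the series" means these compounds.

- compound 1 `COc1ccccc1NC(=O)N1CCN(c2ncnc3sc(-c4ccc(N5CCN(C)CC5)cc4)cc23)CC1`: 26300 nM
- compound 2 `CN1CCN(c2ccc(-c3cc4c(N5CCN(C(=O)Nc6ccc(Cl)c(C(F)(F)F)c6)CC5)ncnc4s3)cc2)CC1`: 3500 nM

In a functional assay on MDA-MB-436 cells (Homo sapiens) for antiproliferative activity, read by MTT assay, with a stated time of 48 h (a lower number here means a stronger inhibitor, a higher number a weaker inhibitor), compound 2 holds the lower of the two values, at 3500 nM. Unmeasured compound 3 `CC(C)c1cccc(C(C)C)c1NC(=O)N1CCN(c2ncnc3sc(-c4ccc(N5CCN(C)CC5)cc4)cc23)CC1` differs from compound 2 as follows: 2,6-diisopropylphenyl in place of 4-chloro-3-(trifluoromethyl)phenyl on an amide-type nitrogen. Going by the values given here, one measured step bears on this nitrogen, a 7.5-fold lower number from compound 1 to compound 2 (0.88 log units; beyond the scatter), a modest change. Neither measured compound carries 2,6-diisopropylphenyl, so that step sets only a rough scale, and a rise of smaller size is expected from the low position of compound 2. The expected change is a 2.9-fold higher number from compound 2 to compound 3 (0.46 log units; beyond the scatter). Compound 3 is estimated at 10000 nM, with an expected range of 3000 nM to 30000 nM.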

Compound 3, half-maximal inhibitory concentration: 11300 nM
Estimate against measurement, compound 3: 1.1-fold (0.05 log units) below; the measured number falls inside the stated range.
By their numbers in this assay, from the lowest: compound 2; then compound 3; then compound 1.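

In this assay the amide-type nitrogen now carries three aryl groups, and 2,6-diisopropylphenyl sits in the middle: a 3.2-fold higher number from compound 2 to compound 3 (0.51 log units; beyond the scatter), while a 2.3-fold lower number from compound 1 to compound 3 (0.37 log units; beyond the scatter). Among these three compounds, a gain over 2-methoxyphenyl therefore does not need chlorine or fluorine atoms, though 4-chloro-3-(trifluoromethyl)phenyl still gives the lowest number. Nothing available explains this order. Still open, on these data alone, is whether an amine or a carboxylic acid on this aryl ring, or a longer alkyl chain in its place, would lower the number further.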